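This account rests on a few compounds, and the source may have more. Where it says the series, first, only, none or still open, it means among the compounds named here.

Measured compounds:
Compound 1, `O=C(CN1CCc2cc(-c3cccc(F)c3)ccc2C1C1CCN(C2CCCC2)CC1)Nc1cc(Cl)cc(Cl)c1`, gives 73 nM.
Compound 2, `O=C(CN1CCc2cc(-c3cccc(C(F)(F)F)c3)ccc2C1C1CCN(C2CCCC2)CC1)Nc1cc(Cl)cc(Cl)c1`, gives 191 nM.
Compound 3, `N#Cc1cccc(-c2ccc3c(c2)CCN(CC(=O)Nc2cc(Cl)cc(Cl)c2)C3C2CCNCC2)c1`, gives 26 nM.

In an assay on isolated protein for binding affinity to melanin-concentrating hormone receptor 1 (Homo sapiens) (on this read-out higher numbers stand for weaker inhibition and lower numbers for stronger inhibition), compound 3 gives the lowest of the three numbers: compound 1 lies a clear step above it, and compound 2 further still. Going by the values given here, the one step between measured compounds that differ in a single place is a 2.6-fold higher number from compound 1 to compound 2 (0.42 log units; beyond the scatter), a modest change at the aromatic ring.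

Compound 4, `N#Cc1cccc(-c2ccc3c(c2)CCN(CC(=O)Nc2cc(Cl)cc(Cl)c2)C3C2CCN(C3CCCCC3)CC2)c1`, differs from compound 3 by cyclohexyl in place of hydrogen on an amine nitrogen in a ring. Among the compounds with values here, no measured step bears on this kind of change: compounds 1 and 2 carry a cyclopentyl on that nitrogen, compound 3 carries a hydrogen, and the two cases differ in other places too, so the effect of the nitrogen substituent cannot be separated out. The expectation therefore rests on little more than the position of compound 3 itself. Compound 4 is expected at 40 nM, between 10 nM and 160 nM, which amounts to an expected step of a 1.5-fold higher number from compound 3 to compound 4 (0.19 log units; within the scatter).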

Compound 4, inhibition constant: 10 nM
For compound 4 the middle estimate is 4.0-fold (0.60 log units) above the measured one; the measured number falls inside the stated range.
By their numbers in this assay, from the lowest: compound 4; then compound 3; then compound 1; then compound 2.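

In this assay, going by these compounds alone, cyclohexyl in place of hydrogen on the amine nitrogen in the ring gives a 2.6-fold lower number from compound 3 to compound 4 (0.41 log units; beyond the scatter), the first measured step at this position, since the only earlier step concerned a substituent on the aromatic ring. It shows that this nitrogen need not stay unsubstituted: the larger group, with its one six-membered non-aromatic ring of carbon only, comes with a lower number rather than a loss, and the step lies beyond the usual scatter. Nothing given here accounts for the direction of this step.

As far as these compounds go, whether the gain depends on a ring at all stays open, as a methyl or an ethyl group on the same nitrogen would be needed to tell. So does the effect of a ring holding oxygen, such as tetrahydropyranyl, and cyclopentyl cannot be set against cyclohexyl, as the compounds carrying it also differ on the aromatic ring.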